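Acetylation of the hydroxyl in the amino-hydroxypropyl series

This account rests on a few compounds, and the source may have more. Where it says the series, first, only, none or still open, it means among the compounds named here.

Three analogues sharing one core have been measured in an assay on HeLa cells for inhibition of sphingosine-1-phosphate transporter SPNS2 (Mus musculus), read by LC-MS, tested at 2 uM; on this read-out higher numbers stand for more inhibition at the one concentration tested (going by the name of the read-out) and lower numbers for less inhibition. Compound 1 `CCCCCCCCCCc1ccc(-c2noc([C@H]3CCCN3)n2)cc1` gives 12%. Compound 2 `CCCCCCCCCCc1ccc(-c2noc(-c3cccc(CN)c3)n2)cc1` gives 2%, and the step of a number 10 percentage points lower from compound 1 to compound 2 (within the scatter) stays within the scatter. Compound 3 `CCCCCCCCCCc1ccc(-c2noc(CC(O)CN)n2)cc1` gives 59% and stands highest of the three; the steps of a number 47 percentage points higher from compound 1 to compound 3 (beyond the scatter) and a number 57 percentage points higher from compound 2 to compound 3 (beyond the scatter) are both beyond the scatter.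

Compound 4 `CCCCCCCCCCc1ccc(-c2noc(CC(CN)OC(C)=O)n2)cc1` is not yet measured. Relative to compound 3 the change is acetyl in place of hydrogen on an oxygen on a saturated carbon. Among the compounds with values here, none of the measured steps bears directly on this: the two large steps exchanged the whole group on the aromatic carbon, and no step alters only the hydroxy group. The effect of capping the hydroxy as acetoxy is therefore unknown on these data, so a wide range is appropriate. A moderate loss is expected, with the step of a number 17 percentage points lower from compound 3 to compound 4 (beyond the scatter) given as the estimate. Compound 4 is expected to give 42%, within 15% to 70% in this assay.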

Compound 4, a percentage reported as inhibition, at one concentration (the size of the read-out at that concentration, not a potency): 0%
Compound 4: the middle estimate sits 42 percentage points above what was measured, outside the stated range (below it).
By their numbers in this assay, from the lowest: compounds 4, 2 and 1 (each within the scatter of the next, the first and the last beyond it); then compound 3.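

Capping the hydroxy as acetoxy is the first change in the series confined to this oxygen on a saturated carbon, and in this assay the number is lower: a number 59 percentage points lower from compound 3 to compound 4 (beyond the scatter) is a large step, so the 3-amino-2-hydroxypropyl chain does not keep its number once the acetyl enters. The acetoxy compound no longer stands apart from the other two analogues, with a number 2 percentage points lower from compound 2 to compound 4 (within the scatter) read as a step inside the scatter and a number 12 percentage points lower from compound 1 to compound 4 (beyond the scatter) read as a modest step. The data give no explanation for the size of this loss.

On these data alone, whether a methoxy group, a fluorine or a plain hydrogen in place of the hydroxy would keep the number of compound 3 stays open. So does the effect of an acetyl on the amine, with the hydroxy left free.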